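From a selenium-bearing amide to a bromine-bearing one

The source may hold more compounds than are shown below. What is called first, only, known or untested is meant among the compounds shown, and "the series" means these compounds.

Of the compounds shown here, three have been measured in a functional assay on HCT-116 cells (Homo sapiens) for inhibition, read by MTT assay, with a stated time of 48 h; on this read-out higher numbers stand for weaker inhibition and lower numbers for stronger inhibition. Compound 1 `C/C=C/C(=O)N(Cc1cc(OC)c(OC)c(OC)c1)c1ccc(OC)c(O)c1` gives 8450 nM, compound 2 `COc1ccc(CNc2cc(OC)c(OC)c(OC)c2)cc1` gives 18400 nM, and compound 3 `COc1ccc(CN(C(=O)C[Se]C#N)c2cc(OC)c(OC)c(OC)c2)cc1O` gives 310 nM. Compound 3 stands lowest of the three numbers; its nearest neighbour is compound 1, whose number is higher by a margin beyond the scatter, and compound 2 lies further still. Compound 4 `COc1ccc(CN(C(=O)C(C)Br)c2cc(OC)c(OC)c(OC)c2)cc1O` has not yet been measured and differs from compound 3 in one place: a group of 3 heavy atoms (2 carbon, 1 bromine; no ring) in place of a group of 4 heavy atoms (2 carbon, 1 nitrogen, 1 selenium; no ring), on a carbonyl carbon. Going by the values given here, no step between measured compounds of this kind is known, so the outcome rests on expectation alone. Compound 4 is expected to come out somewhat weaker, with an estimated step of a 2.9-fold higher number from compound 3 to compound 4 (0.46 log units; beyond the scatter). Compound 4 is therefore estimated at 900 nM in this assay, within a range from 200 nM to 4000 nM.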

Compound 4, half-maximal inhibitory concentration: 140 nM
Compound 4: middle estimate off by 6.4-fold (0.81 log units), on the high side; measured number below the stated range.
By their numbers in this assay, from the lowest: compound 4; then compound 3; then compound 1; then compound 2.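

In this assay, putting 1-bromoethyl on the carbonyl carbon in place of the selenium-bearing group gives a 2.2-fold lower number from compound 3 to compound 4 (0.35 log units; beyond the scatter), a modest step. This position therefore does not depend on selenium or a nitrile for a number in this range, since compound 4 carries neither and still gives the lowest number of the four compounds. Nothing available explains the direction of this step. Going by these compounds, what remains open is whether the bromine itself matters. The compounds shown do not tell how a plain ethyl group, a chlorine-bearing chain, an amine or a carboxylic acid would fare on this carbonyl carbon.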